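The source may hold more compounds than are shown below. What is called first, only, known or untested is meant among the compounds shown, and "the series" means these compounds.

The series shares one core and varies the ring on the sulfonamide nitrogen. Compound 1 `CCc1ccccc1NS(=O)(=O)c1ccc(N2CCNC2=O)cc1` gives 350 nM in a functional assay on MCF7 cells (Homo sapiens) for antiproliferative activity, read by sulforhodamine B assay, with a stated time of 48 h; a higher number here means a weaker inhibitor, a lower number a stronger inhibitor. For the measured compounds named here, compound 2 `COc1ccccc1NS(=O)(=O)c1ccc(N2CCNC2=O)cc1` gives 770 nM in this assay; the step of a 2.2-fold higher number from compound 1 to compound 2 (0.34 log units; beyond the scatter) is the only single-point change measured so far. Compound 3 `O=C1NCCN1c1ccc(S(=O)(=O)Nc2cccc(Oc3ccccc3)c2)cc1` gives 220 nM in this assay, the lowest of the three numbers, though its gap to compound 1 is within the scatter and only compound 2 stands clearly higher.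

Compound 4 `Cc1cccc(NS(=O)(=O)c2ccc(N3CCNC3=O)cc2)c1` differs from compound 3 by methyl in place of phenoxy on an aromatic carbon. Going by the values given here, no measured step removes a phenoxy or exchanges a group of that size; the step from compound 1 to compound 2 swaps two small groups and was modest, so it bears on the change only loosely. With the large group gone and a single carbon in its place, the number is expected to rise somewhat rather than fall, the step of a 2.7-fold higher number from compound 3 to compound 4 (0.44 log units; beyond the scatter) being the estimated size. Compound 4 is therefore expected to give about 600 nM in this assay, within a range of 250 nM to 1500 nM.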

Compound 4, half-maximal inhibitory concentration: 190 nM
Compound 4: the middle estimate sits 3.2-fold (0.50 log units) above what was measured; the measured number lies below the stated range.
By their numbers in this assay, from the lowest: compounds 4, 3 and 1 (each within the scatter of the next); then compound 2.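

In this assay, phenoxy can give way to methyl on this aromatic carbon, meta to a large group, without a readable shift (a 1.2-fold lower number from compound 3 to compound 4 (0.06 log units; within the scatter)), so the six-membered aromatic ring of the phenoxy is not needed to keep the number in this range. For the compounds shown here, the exchange of the whole ring on the sulfonamide nitrogen also stays within the scatter for 3-methylphenyl against 2-ethylphenyl (a 1.8-fold lower number from compound 1 to compound 4 (0.27 log units; within the scatter)), whereas 3-methylphenyl against 2-methoxyphenyl goes beyond it (a 4.1-fold lower number from compound 2 to compound 4 (0.61 log units; beyond the scatter)), which leaves compound 2 as the one compound apart from the other three. No evidence at hand explains this flat response to the size of the group.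

As far as these compounds go, whether an amine or a carboxylic acid at this carbon would hold the number stays open. So does whether methoxy at this same place would match methyl or follow compound 2.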